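A few compounds are considered here, and "the series" means these few. Any claim that something is new, unique, unknown or untested is made for them only; others in the source may bear on it.

Compound 3 `CC[C@H](C)[C@H](NC(=O)c1cccc(Cn2ccnc2)c1)C(=O)NNS(=O)(=O)c1ccccc1` gives the higher of the two numbers in an assay on HEK293 cells for displacement of a labelled ligand from Type-2 angiotensin II receptor (Homo sapiens), tested at 10 uM (on this read-out higher numbers stand for a stronger effect at the one concentration tested and lower numbers for a weaker effect), with compound 1 `CCCCNC(=O)[C@@H](NC(=O)c1cccc(Cn2ccnc2)c1)[C@@H](C)CC` standing lower: compound 3 gives 18%, while compound 1 gives 3%. Compound 2 `CCCCS(=O)(=O)NNC(=O)[C@@H](NC(=O)c1cccc(Cn2ccnc2)c1)[C@@H](C)CC` has no result in this assay, reported as "not determined" (no result reported). Compound 4 `CC[C@H](C)[C@H](NC(=O)c1cccc(Cn2ccnc2)c1)C(=O)NC#N` differs from compound 3 in one place: cyano in place of (phenylsulfonyl)amino on an amide-type nitrogen. Within the data shown here, the only measured step that bears on this position is a number 15 percentage points higher from compound 1 to compound 3 (beyond the scatter). That step shows the read-out rising when (phenylsulfonyl)amino enters; removing it again in favour of cyano is therefore expected to move the number back down, by about a number 11 percentage points lower from compound 3 to compound 4 (beyond the scatter). Compound 4 is expected to give 7% in this assay, within a range from 0% to 22%.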

Compound 4, a percentage reported as inhibition, at one concentration (the size of the read-out at that concentration, not a potency): 9%
Compound 4: middle estimate off by 2 percentage points, on the low side, and the stated range covers the measured number.
By their numbers in this assay, from the lowest: compounds 1, 4 and 3 (each within the scatter of the next, the first and the last beyond it).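

On the amide-type nitrogen, cyano in place of (phenylsulfonyl)amino gives a number 9 percentage points lower from compound 3 to compound 4 (within the scatter), and cyano in place of butyl gives a number 6 percentage points higher from compound 1 to compound 4 (within the scatter). In this assay, among these compounds, compound 4 therefore cannot be told apart from either compound 1 or compound 3, so the only step at this position beyond the scatter remains a number 15 percentage points higher from compound 1 to compound 3 (beyond the scatter). No measurement shown here explains these numbers. Still open, going by these compounds, is how a carboxylic acid, a longer alkyl chain or a benzyl group would read on this nitrogen.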